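The compounds below may be only part of what the source reports. "The series", "measured", "known", "first", "only" and "open" are said of these compounds alone.

Compound 1 `COCc1nc2nc(C)cc(Nc3ccc(S(F)(F)(F)(F)F)cc3)n2n1`: 5.6 mL.min-1.g-1
Compound 2 `COCc1nc2nc(C)cc(Nc3ccc(C(F)(F)F)cc3)n2n1`: 6.7 mL.min-1.g-1
Compound 3 `Cc1cc(Nc2ccc(C(F)(F)F)cc2)n2nc(C3CC3)nc2n1`: a limit of the assay, not a number, < 5 mL.min-1.g-1

All three were run in an in vitro ADME assay on microsomes from liver (Homo sapiens) for metabolic stability; on this read-out higher numbers stand for fast clearance and lower numbers for slow clearance. Compound 1 stands lowest of the two plain numbers; the nearest is a 1.2-fold higher number from compound 1 to compound 2 (0.08 log units; within the scatter). Compound 3 sits at the limit of < 5 mL.min-1.g-1 in this assay, at which 1 of the 3 values shown sits.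

The unmeasured compound 4 `CCC(F)(F)c1nc2nc(C)cc(Nc3ccc(S(F)(F)(F)(F)F)cc3)n2n1` differs from compound 1 at a single place: 1,1-difluoropropyl in place of methoxymethyl on an aromatic carbon. Of the measured steps, the one closest in kind is an at least 1.3-fold lower number from compound 2 to compound 3 (0.12 log units; that floor lies within the scatter), where a substituent on the same aromatic carbon of the shared core was exchanged and the number did not move beyond the scatter. The exchange of the group on the six-membered ring, a 1.2-fold higher number from compound 1 to compound 2 (0.08 log units; within the scatter), also stayed within the scatter. Going by the values given here, no measured step reaches beyond the scatter, so no change beyond the scatter is expected here either.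

Compound 4 is therefore estimated at 5 mL.min-1.g-1, with a range from 2.5 mL.min-1.g-1 to 10 mL.min-1.g-1. That estimate means a 1.1-fold lower number from compound 1 to compound 4 (0.05 log units; within the scatter), expected to lie within the scatter. Because compound 3 already sits at the limit of < 5 mL.min-1.g-1 in this assay, at which 1 of the 3 values shown sits, compound 4 may also be reported only as a limit.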

Compound 4, intrinsic clearance in microsomes: < 5 mL.min-1.g-1
Compound 4 was reported as a limit; the forecaster's own chance of this, stated with the estimate: 40%; the middle value lies on the limit itself.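

In this assay, putting 1,1-difluoropropyl in place of methoxymethyl on the aromatic carbon between two ring nitrogen atoms gives an at least 1.1-fold lower number from compound 1 to compound 4 (0.04 log units; that floor lies within the scatter). This position therefore accepts a larger group with two fluorine atoms and no hydrogen-bond acceptor, with no sign of faster clearance, something the smaller cyclopropyl of compound 3 could not show on the core of compound 1. Compound 4 gives a limit of the assay, not a number, so the true size of this step cannot be read: the limit of < 5 mL.min-1.g-1 in this assay, at which 2 of the 4 values shown sit.

As far as these compounds go, how far compound 4 lies under that limit stays open, as does whether an amine or a carboxylic acid on this aromatic carbon would keep clearance this slow. A plain propyl chain would separate the part played by the two fluorine atoms from that of the chain itself.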